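This account rests on a few compounds, and the source may have more. Where it says the series, first, only, none or still open, it means among the compounds named here.

Compound 1 `O=C(CCCCCCCCCCCc1ccccc1)CC(=O)N[C@H]1CCOC1=O`: 4000 nM
Compound 2 `O=C(CCCc1ccccc1)N[C@H]1CCOC1=O`: > 100000 nM (a limit of the assay)

Among the measured compounds shown here, in a functional assay on PC-3 cells (Homo sapiens) for cytotoxicity, read by sulforhodamine B assay, with a stated time of 5 days (a lower number here means a stronger inhibitor, a higher number a weaker inhibitor), compound 1 gives 4000 nM, the only exact number so far. The entry for compound 2, > 100000 nM, is a limit and not a number.

Compound 3 `O=C(CCCCCCCCCCc1ccccc1)CC(=O)N[C@H]1CCOC1=O` has not yet been measured. It differs from compound 1 by phenyl in place of benzyl on a saturated chain carbon, ten or more bonds along the chain from a carbonyl carbon. For the measured compounds named here, no measured pair shows this change directly. The expected step of a 1.3-fold higher number from compound 1 to compound 3 (0.10 log units; within the scatter) is small, with no clear direction and no size beyond the usual scatter. For compound 3 the estimate is 5000 nM, with an expected range of 1800 nM to 14000 nM.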

Compound 3, half-maximal inhibitory concentration: 2000 nM
Compound 3: the middle estimate sits 2.5-fold (0.40 log units) above what was measured; low and high end bracket the measured number.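

Phenyl in place of benzyl on a saturated chain carbon gives a 2.0-fold lower number from compound 1 to compound 3 (0.30 log units; within the scatter) in this assay and so provides the first direct reading of this change. For this one pair, the two compounds cannot be told apart, so the change at this place has no effect that can be read. Nothing measured here offers a cause for this result.

On these data alone, whether an amine or a carboxylic acid at the chain end would give a similar number remains open.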